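The source may hold more compounds than are shown below. What is called first, only, known or untested is meant among the compounds shown, and "the series" means these compounds.

Compound 1 `CN(C)C(=O)c1cc2cnc(Nc3ccc(NC(=O)C4(C(=O)Nc5ccc(F)cc5)CC4)cc3)nc2n1C1CCCC1`: 102%
Compound 2 `CN(C)C(=O)c1cc2cnc(Nc3ccc(NC(=O)C4(C(=O)Nc5cccc(O)c5)CC4)cc3)nc2n1C1CCCC1`: 94.9%

Among the compounds with values here, in a functional assay on NCI-H460 cells (Homo sapiens) for inhibition, read by CCK-8 assay, with a stated time of 72 h, tested at 10 uM (on this read-out lower numbers stand for less inhibition of growth and higher numbers for more inhibition of growth at the one concentration tested), compound 1 gives 102%, the higher of only two numbers, but the one measured step, a number 7.1 percentage points lower from compound 1 to compound 2 (within the scatter), does not separate them. Compound 3 `CN(C)C(=O)c1cc2cnc(Nc3ccc(NC(=O)C4(C(=O)Nc5ccc(F)cc5)CC4)cc3F)nc2n1C1CCCC1` keeps the 4-fluorophenyl of compound 1 and differs from it by fluoro in place of hydrogen on an aromatic carbon. That one measured step swaps 3-hydroxyphenyl for 4-fluorophenyl on an amide-type nitrogen, elsewhere in the molecule, so it bears only indirectly on fluoro in place of hydrogen on an aromatic carbon. No step beyond the scatter is therefore expected in this assay. The expected step is a number 7 percentage points lower from compound 1 to compound 3 (within the scatter). Compound 3 is estimated at 95%, with a range of 78% to 106%.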

Compound 3, percent growth inhibition at one concentration: 53%
Beside the measured number, compound 3's estimate is 42 percentage points above it; measured number below the stated range.
By their numbers in this assay, from the lowest: compound 3; then compounds 2 and 1 (each within the scatter of the next).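

In this assay, fluoro in place of hydrogen on an aromatic carbon, ortho to a large group and meta to a large group, gives a number 49 percentage points lower from compound 1 to compound 3 (beyond the scatter). One added heavy atom at this place therefore moves the read-out well beyond the scatter, whereas the change on the amide-type nitrogen gives a number 7.1 percentage points lower from compound 1 to compound 2 (within the scatter). Nothing at hand bears on the reason for the step.

Open, on these data alone, is whether the step is specific to fluoro or follows any group at this place, which a chloro, methyl or methoxy group there would test. Also open, as far as these compounds go, is whether fluoro on the other carbons of this ring gives a step of similar size.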